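The source may hold more compounds than are shown below. What is called first, only, known or untested is meant among the compounds shown, and "the series" means these compounds.

Working notes on the series.

For the measured compounds named here, compound 1 `CCCCOc1nc(N)nc2[nH]cnc12` is the one compound with a number in an assay on HT-29 cells for inhibition of Methylated-DNA--protein-cysteine methyltransferase (Homo sapiens); on this read-out lower numbers stand for stronger inhibition and higher numbers for weaker inhibition: compound 1 gives 493000 nM. Compound 2 `CC1(C)OCC(COc2nc(N)nc3[nH]cnc23)O1` belongs to the same core. In this assay compound 2 reaches only a limit of the assay, > 1000000 nM, and no number. Of the two values shown, one is therefore a number and one a limit, as the evidence summarises: the limit of > 1000000 nM in this assay, at which 1 of the 2 values shown sits. Compound 1 thus stands as the only measured point on which an expectation can rest; the value of compound 2 shows no more than that it lies past the limit.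

Compound 3 `CC(=O)COc1nc(N)nc2[nH]cnc12` is not yet measured in this assay. Its difference from compound 1 is acetyl in place of propyl on a saturated chain carbon bound to an oxygen on an aromatic ring. Going by the values given here, no step between measured compounds that differ in one place is available for this series, so the direction of this change is without precedent here. The expectation is a step of a 1.0-fold higher number from compound 1 to compound 3 (0.01 log units; within the scatter) of no size beyond the usual scatter. For compound 3 the estimate in this assay is 500000 nM, with a range from 150000 nM to 1500000 nM.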

Compound 3, half-maximal inhibitory concentration: 192000 nM
For compound 3 the middle estimate is 2.6-fold (0.42 log units) above the measured one; the measured number falls inside the stated range.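

In this assay this position now carries its first readable step, a 2.6-fold lower number from compound 1 to compound 3 (0.41 log units; beyond the scatter), so acetyl in place of propyl on a saturated chain carbon bound to an oxygen on an aromatic ring does change the read-out. Cut one bond further out, the same difference reads butoxy to 2-oxopropoxy: the leaving and entering groups have the same heavy-atom count, and the entering group brings a carbonyl with a hydrogen-bond acceptor, yet compound 3 still gives a high number on this read-out, 192000 nM. The values shown give no measured basis for explaining this step.

A single step at a single place leaves open whether the lower number follows the carbonyl itself or some other part of the swap of propyl for acetyl. From the compounds shown here alone, whether the same direction holds for a hydroxyl, an amine or a carboxylic acid on this chain, or for a longer chain ending in a ketone, also remains open.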